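Cytotoxicity at the limit: propylamino to butylsulfanyl

The source may report more compounds than this note shows. Statements on the series, on what has been measured and on what is new or still open speak of the compounds shown alone.

The three measured analogues share one core and differ only in the group on the aromatic carbon. Compound 1 `CCCCCCCCOc1nc(N)nc2c1ncn2/C=C1/CC1(CO)CO` carries octyloxy there, compound 2 `CN(C)c1nc(N)nc2c1ncn2/C=C1/CC1(CO)CO` dimethylamino, compound 3 `CCCNc1nc(N)nc2c1ncn2/C=C1/CC1(CO)CO` propylamino. In an ADME assay on Akata cells (Homo sapiens) for cytotoxicity, with a stated time of 7 days (on this read-out higher numbers stand for lower toxicity in this test and lower numbers for higher toxicity in this test), compound 1 gives > 20000 nM, a limit of the assay and not a number. In this assay compound 2 gives > 24000 nM, likewise a limit. In this assay compound 3 gives > 24000 nM, again only a limit. Compound 3 thus stands where the other two stand, at the limit, and the limit of > 24000 nM in this assay, at which 2 of the 3 values shown sit, together with the limit of > 20000 nM in this assay, at which 1 of the 3 values shown sits, is all the series shows. Accordingly a step that the two limits leave unreadable from compound 1 to compound 3 and a step that the two limits leave unreadable from compound 2 to compound 3 cannot be sized, nor can a step that the two limits leave unreadable from compound 1 to compound 2.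

Compound 4 `CCCCSc1nc(N)nc2c1ncn2/C=C1/CC1(CO)CO` is the next analogue; the change is butylsulfanyl in place of propylamino on an aromatic carbon. For the measured compounds named here, no measured step bears on it in readable size; every group so far tried at that carbon left cytotoxicity at the limit in this assay. The expected step that the limit leaves unreadable from compound 3 to compound 4 is none beyond the scatter. Compound 4 is estimated to reach 30000 nM, in the range 15000 nM to 60000 nM, most likely as a limit.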

Compound 4, half-maximal cytotoxic concentration: > 20000 nM
Compound 4: a limit, no number; the forecaster's own chance of this, stated with the estimate: 85%; the middle value is on the limit's open side.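

Compound 4, like compound 1, compound 2 and compound 3, gives only a limit in this assay, so the steps from compound 1, compound 2 and compound 3 to compound 4 cannot be read. The compounds shown leave open whether any group at that aromatic carbon gives a measurable cytotoxic concentration in this assay.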